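Series of 2-aryl-4-anilinoquinazoline analogues: shift to 4-methylphenyl

A few compounds are considered here, and "the series" means these few. Any claim that something is new, unique, unknown or untested is made for them only; others in the source may bear on it.

Measured compounds:
Compound 1, `Fc1cccc(-c2nc(Nc3ccccc3F)c3cc(F)ccc3n2)c1`. In a functional assay on MDA-MB-231 cells (Homo sapiens) for cytotoxicity, read by MTT assay, with a stated time of 48 h (on this read-out lower numbers stand for stronger inhibition and higher numbers for weaker inhibition), compound 1 gives > 50000 nM, which is a limit of the assay and not a number.
Compound 2, `Fc1cccc(-c2nc(Nc3ccccc3Cl)c3cc(F)ccc3n2)c1`. In this assay compound 2 gives > 50000 nM, again a limit of the assay.
Compound 3, `Fc1cccc(-c2nc(Nc3ccccc3Br)c3cc(F)ccc3n2)c1`. In this assay compound 3 gives > 50000 nM, also a limit of the assay.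

Compound 2 therefore stands at the same limit as the other two measured members of the series; all three sit at the limit of > 50000 nM in this assay, at which 3 of the 3 values shown sit, and no ordering among them can be read. The steps a step that the two limits leave unreadable from compound 1 to compound 2, a step that the two limits leave unreadable from compound 1 to compound 3 and a step that the two limits leave unreadable from compound 2 to compound 3 are unreadable in size, so nothing is known about how halogen exchange on the anilino ring moves the read-out.

The next compound, compound 4, `Cc1ccc(Nc2nc(-c3cccc(F)c3)nc3ccc(F)cc23)cc1`, differs from compound 2 by 4-methylphenyl in place of 2-chlorophenyl on a nitrogen on an aromatic ring. For the measured compounds named here, no measured step bears directly on this change: the three measured steps all concern halogen exchange at one position and are hidden by the limit, whereas here the substituent type and its place on the ring both change. Compound 4 is thus expected to stay near the limit, with the step from compound 2 to compound 4 estimated as an at least 1.1-fold lower number from compound 2 to compound 4 (0.04 log units; that floor lies within the scatter). Compound 4 is estimated at 45000 nM in this assay, with a range from 8000 nM to 100000 nM.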

Compound 4, half-maximal inhibitory concentration: > 50000 nM
Compound 4: only a limit was reported; the forecaster's own chance of this, stated with the estimate: 65%; middle value at least 1.1-fold (0.04 log units) away from the limit.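

Compound 4 sits at a limit of the assay, as do compound 1, compound 2 and compound 3, so the steps from these three to compound 4 cannot be read: the limit of > 50000 nM in this assay, at which 4 of the 4 values shown sit. Still open, as far as these compounds go, is whether any group on this nitrogen moves the read-out at all.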